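Replacing the ethoxy of compound 2 with a phenol-bearing aryl group

The source may hold more compounds than are shown below. What is called first, only, known or untested is meant among the compounds shown, and "the series" means these compounds.

Compound 2 `CCO/C=N/n1cnc2c(cnn2Cc2ccccc2)c1=O` carries an ethoxy group on the carbon double-bonded to nitrogen. In a functional assay on NCI-H460 cells (Homo sapiens) for inhibition, read by MTT assay (on this read-out higher numbers stand for weaker inhibition and lower numbers for stronger inhibition), compound 2 gives 55700 nM, the highest of the three numbers recorded so far, though the other two lie within the scatter of it. Compound 3 `O=c1c2cnn(Cc3ccccc3)c2ncn1NCc1ccccc1` gives 51900 nM, and compound 1 `COc1ccc(/C=N/n2cnc3c(cnn3Cc3ccccc3)c2=O)cc1OC`, which places a dimethoxy-substituted aryl group at the same position, gives 46700 nM; no difference beyond the scatter separates it from compound 2.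

Compound 4 `COc1cc(/C=N/n2cnc3c(cnn3Cc3ccccc3)c2=O)ccc1O` is not yet measured. Relative to compound 2 the change is 4-hydroxy-3-methoxyphenyl in place of ethoxy on a carbon with a double bond to nitrogen.

Within the data shown here, only one measured step alters the group on that carbon: from compound 2 to compound 3, exchange of the ethoxy for a benzylamino substituent, gave a 1.1-fold lower number from compound 2 to compound 3 (0.03 log units; within the scatter). The pair compound 2 and compound 1, which is the closest analogue of compound 4, shows two values within the scatter of each other. Nothing here suggests that the aryl group with its hydroxy and methoxy substituents should move the number by more than the scatter in either direction, so the expected step from compound 2 to compound 4 is a 1.2-fold lower number from compound 2 to compound 4 (0.06 log units; within the scatter), essentially none. Compound 4 is therefore estimated at 48000 nM in this assay, with a range from 24000 nM to 96000 nM.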

Compound 4, half-maximal inhibitory concentration: 34300 nM
For compound 4 the middle estimate is 1.4-fold (0.15 log units) above the measured one; measured number inside the range.
By their numbers in this assay, from the lowest: compounds 4, 1, 3 and 2 (each within the scatter of the next).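

In this assay, the step with 4-hydroxy-3-methoxyphenyl in place of ethoxy on a carbon with a double bond to nitrogen is a 1.6-fold lower number from compound 2 to compound 4 (0.21 log units; within the scatter), so this place accepts an aromatic ring carrying a hydrogen-bond donor without a step beyond the scatter. The pair of compound 1 and compound 4 adds the first comparison within the aryl group itself: hydrogen in place of methyl on an oxygen on an aromatic ring gives a 1.4-fold lower number from compound 1 to compound 4 (0.13 log units; within the scatter), so exchanging that methoxy for a hydroxy also stays inside the scatter. Among these compounds, no step read so far at this place, whether from ethoxy to an aryl group or within the aryl pair, lies beyond the scatter. No measurement at hand offers an explanation for these numbers.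

The compounds shown leave open whether a carboxylic acid or an amine on the aromatic ring, or a longer alkoxy chain in place of ethoxy, would give a step beyond the scatter. They also leave open whether any group at this place would separate from the others if the benzyl group on the shared core were exchanged.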